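Dihydroxyphenyl for Dimethoxyphenyl Repeated on a Second Core

The source may hold more compounds than are shown below. What is called first, only, known or untested is meant among the compounds shown, and "the series" means these compounds.

Compound 1 `COc1ccc(Oc2ccc(C(C)C)cc2-c2ccsc2S(=O)(=O)NCCNC(=S)Nc2ccc([N+](=O)[O-])cc2)cc1OC` was tested in a functional assay on HL-60 cells (Homo sapiens) for inhibition, read by CCK-8 assay, with a stated time of 48 h (on this read-out lower numbers stand for stronger inhibition and higher numbers for weaker inhibition), where compound 1 gives 11200 nM. Compound 2 `CC(C)c1ccc(Oc2ccc(O)c(O)c2)c(-c2ccsc2S(=O)(=O)NCCNC(=S)Nc2ccc([N+](=O)[O-])cc2)c1` carries the change (3,4-dihydroxyphenyl in place of 3,4-dimethoxyphenyl on an oxygen on an aromatic ring), and in this assay compound 2 gives 8800 nM. The step of a 1.3-fold lower number from compound 1 to compound 2 (0.10 log units; within the scatter) therefore does not separate the two compounds. Compound 3 `COc1ccc(Oc2ccccc2-c2ccsc2S(=O)(=O)N2CCN(C(=S)Nc3ccc(Cl)cc3)CC2)cc1OC` belongs to a different core; how the core of compound 3 differs from the core of compound 1 is not broken down here. In this assay compound 3 reaches only a limit of the assay, > 50000 nM, and this is the one case of the limit of > 50000 nM in this assay, at which 1 of the 3 values shown sits, among the three measured values.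

Compound 4 `O=S(=O)(c1sccc1-c1ccccc1Oc1ccc(O)c(O)c1)N1CCN(C(=S)Nc2ccc(Cl)cc2)CC1` is the unmeasured partner of compound 3 and carries the change (3,4-dihydroxyphenyl in place of 3,4-dimethoxyphenyl on an oxygen on an aromatic ring), the same change that separates compound 1 from compound 2, at the same place. The expected step of a number no higher from compound 3 to compound 4 (the limit leaves the size open) for compound 4 is small because a 1.3-fold lower number from compound 1 to compound 2 (0.10 log units; within the scatter) was within the scatter on the first core. Since compound 3 gave only a limit, compound 4 is expected to sit at or near that limit as well, so compound 4 is estimated at 50000 nM in this assay. The estimated range for compound 4 runs from 20000 nM to 100000 nM, and a further limit rather than a number is the most likely outcome for compound 4.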

Compound 4, half-maximal inhibitory concentration: 5500 nM
The estimate for compound 4 lay 9.1-fold (0.96 log units) above the measured number, and the stated range ends above it.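

In this assay the exchange of 3,4-dimethoxyphenyl for 3,4-dihydroxyphenyl, on an oxygen on an aromatic ring, gives an at least 9.0-fold lower number from compound 3 to compound 4 (0.95 log units; beyond the scatter) on the second core, a clear step where the first core showed none beyond the scatter. Set side by side, the two pairs show that this change does not carry over at one size from the core of compound 1 to the core of compound 3: the same change on two cores in this assay, a 1.3-fold lower number (0.10 log units; within the scatter) from compound 1 to compound 2 and an at least 9.0-fold lower number (0.95 log units; beyond the scatter) from compound 3 to compound 4, at least 7.1-fold (0.85 log units) apart, beyond the scatter of two such steps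

Compound 3 gives > 50000 nM, which is a limit of the assay and not a number, so the full size of the step on its core stays open, and the two pairs do not show which feature of the cores sets the steps apart: the limit of > 50000 nM in this assay, at which 1 of the 4 values shown sits.

The compounds shown leave open whether both hydroxyl groups are needed for the step on the second core, and a phenyl ring carrying one hydroxyl group and one methoxy group would speak to that, as would a carboxylic acid or an amine in the place of the hydroxyl groups. They also leave open whether the same change gives a large step, a small one or none on any further core in this series.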